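This account rests on a few compounds, and the source may have more. Where it says the series, first, only, none or still open, it means among the compounds named here.

In a functional assay on Hep 3B2 cells (Homo sapiens) for cytotoxicity, read by MTT assay, with a stated time of 48 h (on this read-out lower numbers stand for stronger inhibition and higher numbers for weaker inhibition), three compounds have been measured so far. Compound 1 `COc1ccc2[nH]c(-c3ccc(F)cc3)cc(=O)c2c1OC` gives > 20000 nM, which is a limit of the assay and not a number. Compound 2 `COc1cc2c(=O)cc(-c3ccccc3F)[nH]c2cc1O` gives 5300 nM. Compound 3 `COc1cc2c(=O)cc(-c3cccc(F)c3)[nH]c2cc1O` gives 5300 nM, which places it level with compound 2.

Compound 4 `COc1cc2c(=O)cc(-c3ccc(F)cc3)[nH]c2cc1O` keeps the core of compound 3 and differs only in the fluorinated ring: 4-fluorophenyl in place of 3-fluorophenyl on an aromatic carbon. It carries 4-fluorophenyl in place of 3-fluorophenyl on an aromatic carbon, next to the ring nitrogen. The two compounds therefore have the same atoms, joined differently.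

Among the measured compounds shown here, one measured step bears directly on this change. It also moves the fluorine around the same ring. Putting 3-fluorophenyl in place of 2-fluorophenyl gave no change at the digits printed from compound 2 to compound 3 (within the scatter). That is a single step, so it is thin evidence, but it offers no reason to expect a large shift when the fluorine moves once more. In this assay, no step beyond the usual scatter is expected, in either direction. The expected step is no change at the digits printed from compound 3 to compound 4 (within the scatter). For compound 4 the estimated value is 5300 nM, with an expected range from 2300 nM to 12000 nM.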

Compound 4, half-maximal inhibitory concentration: > 100000 nM
Compound 4 ended at the assay's limit; the forecaster's own chance of this, stated with the estimate: 10%; middle value at least 18-fold (1.27 log units) away from the limit.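

At this place on the shared core, next to the ring nitrogen, the position of the fluorine on the phenyl ring can matter a great deal in this assay: 4-fluorophenyl in place of 3-fluorophenyl gives an at least 18-fold higher number from compound 3 to compound 4 (1.27 log units; beyond the scatter), and 4-fluorophenyl in place of 2-fluorophenyl gives an at least 18-fold higher number from compound 2 to compound 4 (1.27 log units; beyond the scatter). The earlier result of no change at the digits printed from compound 2 to compound 3 (within the scatter) therefore holds for that pair of groups alone and does not carry over to 4-fluorophenyl. Compound 4 gives > 100000 nM, which is a limit of the assay and not a number: the limit of > 100000 nM in this assay, at which 1 of the 4 values shown sits.

The full size of the two new steps stays open, and the compounds shown give no explanation of why this one move of a single fluorine differs so sharply from the other. Going by these compounds, it is also open whether a different atom or group in the place of that fluorine, such as chlorine, a methoxy group or an amine, would behave like compound 4 or like compound 2 and compound 3.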